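The compounds below may be only part of what the source reports. "The series", "measured", "known", "first", "only" and "open" are said of these compounds alone.

In an ADME assay on 184B5 cells (Homo sapiens) for cytotoxicity, read by MTT assay, with a stated time of 72 h (a higher number here means a weaker inhibitor of growth, a lower number a stronger inhibitor of growth), compound 1 `Sc1nc(NCc2ccccc2)c2ccccc2n1` gives only a limit, > 100000 nM. Going by the values given here, compound 2 `[SeH]c1nc(NCc2ccccc2)c2ccccc2n1` gives 63600 nM in this assay, the one number seen there. The sole further result there is the limit of compound 1. The step of an at least 1.5-fold lower number from compound 1 to compound 2 (0.19 log units; that floor lies within the scatter) thus carries no firm size. Compound 3 `CSc1nc(NCc2ccccc2)c2ccccc2n1` differs from compound 2 in a group of 2 heavy atoms (1 carbon, 1 sulfur; no ring) in place of one selenium atom, on an aromatic carbon. Among the compounds with values here, no measured step touches a methylsulfanyl group, and the only step seen, an at least 1.5-fold lower number from compound 1 to compound 2 (0.19 log units; that floor lies within the scatter), has a floor within the scatter, so in this assay no step beyond the scatter is expected. Compound 3 is expected to give about 90000 nM, between 40000 nM and 200000 nM. The expected step is a 1.4-fold higher number from compound 2 to compound 3 (0.15 log units; within the scatter).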

Compound 3, concentration for total growth inhibition: > 100000 nM
Compound 3 was reported as a limit; the forecaster's own chance of this, stated with the estimate: 40%; middle value at least 1.1-fold (0.04 log units) away from the limit.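

In this assay, methylsulfanyl in place of selenium, on the aromatic carbon between two ring nitrogen atoms, gives an at least 1.5-fold higher number from compound 2 to compound 3 (0.19 log units; that floor lies within the scatter). Methyl on the sulfur therefore does not bring a number into view, and the step between compound 1 and compound 3 cannot be read. Compound 3 is a limit, as compound 1 is, and compound 2 alone gives a number: the limit of > 100000 nM in this assay, at which 2 of the 3 values shown sit.

The compounds shown leave open whether an amine or a longer chain on this carbon would give a number rather than a limit. As far as these compounds go, the firm size of every step also remains open.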